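This account rests on a few compounds, and the source may have more. Where it says the series, first, only, none or still open, it means among the compounds named here.

Measured so far in a functional assay on aorta (Rattus norvegicus) for inhibition (a lower number here means a stronger inhibitor, a higher number a weaker inhibitor), on this series:
- compound 1 `O=C(Nc1cc2cc[nH]c(=O)c2cc1Cl)C1CNCC1c1ccc(F)cc1` gives 160 nM
- compound 2 `O=C(Nc1cc2cc[nH]c(=O)c2cc1Cl)C1CNCC1c1ccccn1` gives 210 nM
- compound 3 `Cc1cccc(C2CNCC2C(=O)Nc2cc3cc[nH]c(=O)c3cc2Cl)c1` gives "not determined" (no result reported)

With no number for compound 3, the step to compound 4 `O=C(Nc1cc2cc[nH]c(=O)c2cc1Cl)C1CNCC1c1ccccc1` has no measured starting point. The change is hydrogen in place of methyl on an aromatic carbon and amounts to 3-methylphenyl to phenyl. Among the compounds with values here, only one measured step bears on it: a 1.3-fold higher number from compound 1 to compound 2 (0.12 log units; within the scatter) puts pyridin-2-yl in place of 4-fluorophenyl on a saturated ring carbon. Within the data shown here, no measured step covers loss of the methyl itself, so neither a size nor a direction can be read for it from compound 3. Compound 4 is therefore expected to sit with the two measured neighbours, with no step beyond the scatter from them. That expectation rests on compound 1 at 160 nM and on compound 2 at 210 nM as the only anchors. Compound 4 is expected at 180 nM (estimated range 80 nM to 400 nM) in this assay once measured.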

Compound 4, half-maximal inhibitory concentration: 89 nM
The estimate for compound 4 lay 2.0-fold (0.31 log units) above the measured number; the range from low to high includes it.
By their numbers in this assay, from the lowest: compounds 4, 1 and 2 (each within the scatter of the next, the first and the last beyond it).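

Within the data shown here, in (this assay), phenyl on the saturated ring carbon gives the first step beyond the scatter, with phenyl in place of pyridin-2-yl (a 2.4-fold lower number from compound 2 to compound 4 (0.37 log units; beyond the scatter)), although that step is modest. Hydrogen in place of fluoro on the aromatic carbon stays within the scatter (a 1.8-fold lower number from compound 1 to compound 4 (0.25 log units; within the scatter)), so compound 1 and compound 4 cannot be separated, and only compound 2 and compound 4 stand apart. No measurement bears on the reason for either step.

Compound 3 has no number, so its step to compound 4 cannot be read and the loss of the methyl remains unsized. From the compounds shown here alone, whether a methoxy group or an amine on the phenyl ring would give a number beyond the scatter from compound 4 also remains open.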